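The source may report more compounds than this note shows. Statements on the series, on what has been measured and on what is new or still open speak of the compounds shown alone.

Working notes on the series. Compound 1 `C=C[C@@H]1OC(c2ccc(Br)cc2)=N[C@H]1S` is the starting point, and in an assay on isolated protein for inhibition of matrix metalloproteinase-9 (Homo sapiens) (a lower number here means a stronger inhibitor, a higher number a weaker inhibitor), compound 1 gives > 100000 nM, which is a limit of the assay rather than a number. Two related compounds carry a hydroxymethyl in place of the sulfanyl. Compound 2 `C=C[C@@H]1OC(CCCCC)=N[C@H]1CO` gives > 2000000 nM in this assay, again a limit and not a number. Within the data shown here, compound 3 `C=C[C@@H]1OC(/C=C/c2ccccc2)=N[C@H]1CO` gives 40000 nM in this assay, the only numeric value in the set. No pair among these three differs in a single place, so no measured step is at hand. Compound 4 `C=C[C@@H]1OC(c2ccc(Br)cc2)=N[C@H]1CO` is not yet measured; it differs from compound 1 by hydroxymethyl in place of sulfanyl on a saturated ring carbon. Compound 1 sits at the limit of > 100000 nM in this assay, at which 1 of the 3 values shown sits, so only a move toward stronger inhibition could appear as a number. Any such move is expected to be small, since compound 2 also sits at the limit of > 2000000 nM in this assay, at which 1 of the 3 values shown sits. Compound 4 is expected at 200000 nM, within 30000 nM to 1500000 nM. The expected step is a step that the limit leaves unreadable from compound 1 to compound 4, quite possibly reported once more as a limit only.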

Compound 4, inhibition constant: 9000 nM
For compound 4 the middle estimate is 22-fold (1.35 log units) above the measured one; the measured number lies below the stated range.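

In this assay, among these compounds, the change of hydroxymethyl in place of sulfanyl on a saturated ring carbon, next to the ring nitrogen, gives an at least 11-fold lower number from compound 1 to compound 4 (1.04 log units; beyond the scatter), the first measured evidence that this position affects the read-out. With the rest of the core of compound 1 unchanged, this single change brings compound 4 to a numeric value of 9000 nM. The true size of the step stays unknown, and the printed size is only a bound, because the value of compound 1 is a limit and not a number: the limit of > 100000 nM in this assay, at which 1 of the 4 values shown sits.

The compounds shown leave open whether the same change has a similar effect when the 4-bromophenyl is replaced by another group. They also leave open how a carboxylic acid or an aminomethyl at this ring carbon would compare with hydroxymethyl.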